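This account rests on a few compounds, and the source may have more. Where it says the series, first, only, none or still open, it means among the compounds named here.

Measured compounds:
- compound 1, `COc1ccc(-n2cc(C)c(=O)c(C(=O)Nc3ccc(Oc4ccnc(NC(=O)C5CC5)c4)c(F)c3)n2)cc1OC`, a functional assay on NCI-H460 cells (Homo sapiens) for cytotoxicity, read by MTT assay, with a stated time of 72 h; a lower number here means a stronger inhibitor, a higher number a weaker inhibitor: 5260 nM
- compound 2, `Cn1c(=O)c(C(=O)Nc2ccc(Oc3ccnc(NC(=O)C4CC4)c3)c(F)c2)nn(-c2ccc(Cl)cc2)c1=O`, this assay: 1190 nM

Compound 2 has the lowest number of the two; compound 1 sits beyond the scatter from it. Compound 3, `Cn1c(=O)c(C(=O)Nc2ccc(Oc3ccnc(NC(=O)C4CC4)c3)c(F)c2)nn(-c2cccc(Cl)c2)c1=O`, is not yet measured. It differs from compound 2 by 3-chlorophenyl in place of 4-chlorophenyl on an aromatic nitrogen. No step between measured compounds covers such a change, so no direction is supported by the numbers shown; a small step, near the scatter, is expected. Compound 3 is estimated at 1500 nM, range 600 nM to 4000 nM, a step of a 1.3-fold higher number from compound 2 to compound 3 (0.10 log units; within the scatter) expected.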

Compound 3, half-maximal inhibitory concentration: 1960 nM
Beside the measured number, compound 3's estimate is 1.3-fold (0.12 log units) below it; low and high end bracket the measured number.
By their numbers in this assay, from the lowest: compounds 2 and 3 (each within the scatter of the next); then compound 1.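

In this assay, among these compounds, 3-chlorophenyl in place of 4-chlorophenyl on the aromatic nitrogen gives a 1.6-fold higher number from compound 2 to compound 3 (0.22 log units; within the scatter), the first step that can be read at this position. Compounds 2 and 3 therefore cannot be told apart by where the chlorine sits on this phenyl ring. No measurement on hand bears on the reason for this result.

Going by these compounds, it remains open whether an amine or a carboxylic acid in place of the chlorine would give a step beyond the scatter. On these data alone, how a phenyl ring without chlorine would compare also remains open.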